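Bromo to chloro on two related oxindole-bearing scaffolds

The source may report more compounds than this note shows. Statements on the series, on what has been measured and on what is new or still open speak of the compounds shown alone.

Compound 1 `COc1ccc(C2=NN(C3=NC(=O)/C(=C4\C(=O)Nc5ccc(Br)cc54)S3)C(c3ccc(Cl)cc3)C2)cc1` and compound 2 `COc1ccc(C2=NN(C3=NC(=O)/C(=C4\C(=O)Nc5ccc(Cl)cc54)S3)C(c3ccc(Cl)cc3)C2)cc1` share one core. In a functional assay on cells (Cancer cell lines, Homo sapiens) for cytotoxicity, read by sulforhodamine B assay, with a stated time of 48 h (on this read-out lower numbers stand for stronger inhibition of growth and higher numbers for weaker inhibition of growth), compound 1 gives 14700 nM, and compound 2 gives 7970 nM. The change between them is chloro in place of bromo on an aromatic carbon, and the step it made was a 1.8-fold lower number from compound 1 to compound 2 (0.27 log units; within the scatter). Compound 3 `CN(C)c1ccc(C2CC(c3ccccc3)=NN2C2=NC(=O)/C(=C3\C(=O)Nc4ccc(Br)cc43)S2)cc1` rests on a different core; the difference between the two cores is not broken down here. In this assay compound 3 gives 690 nM, lower than both compound 1 and compound 2 by margins beyond the scatter. Compound 4 `CN(C)c1ccc(C2CC(c3ccccc3)=NN2C2=NC(=O)/C(=C3\C(=O)Nc4ccc(Cl)cc43)S2)cc1` has not yet been measured; it carries the same change as before, (chloro in place of bromo on an aromatic carbon). The expected step is a 1.4-fold lower number from compound 3 to compound 4 (0.14 log units; within the scatter), resting on compound 1 and compound 2, because a 1.8-fold lower number from compound 1 to compound 2 (0.27 log units; within the scatter) lay within the scatter. Compound 4 is therefore expected to give about 500 nM, with a likely range of 250 nM to 1100 nM.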

Compound 4, concentration for total growth inhibition: 620 nM
Compound 4: middle estimate off by 1.2-fold (0.09 log units), on the low side, within the range that was stated.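

In this assay, chloro in place of bromo on an aromatic carbon gave a 1.1-fold lower number from compound 3 to compound 4 (0.05 log units; within the scatter). Set beside the same change on the other core, the two steps agree: the same change on two cores in this assay, a 1.8-fold lower number (0.27 log units; within the scatter) from compound 1 to compound 2 and a 1.1-fold lower number (0.05 log units; within the scatter) from compound 3 to compound 4, 1.7-fold (0.22 log units) apart, within the scatter of two such steps

The change thus carried across these two cores with no step beyond the scatter on either, so the two halogens are not told apart here. This does not show that it would behave alike on a further core, and as neither step stands clear of the scatter, there is no distinct effect whose size could be said to transfer.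

The compounds shown carry only bromo or chloro at this place. Going by these compounds, what fluoro, a methoxy group or an amine would give there remains open.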